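The source may hold more compounds than are shown below. What is called first, only, known or untested is meant among the compounds shown, and "the series" means these compounds.

Compound 1, `CC(O)(CSc1cccc(S(F)(F)(F)(F)F)c1)C(=O)Nc1cccc(S(F)(F)(F)(F)F)c1`: 12900 nM. Compound 2, `CC(O)(CSc1cccc(C(F)(F)F)c1)C(=O)Nc1cccc(S(F)(F)(F)(F)F)c1`: 12700 nM. Compound 3, `CC(O)(COc1ccc(S(F)(F)(F)(F)F)cc1)C(=O)Nc1cccc(S(F)(F)(F)(F)F)c1`: 8000 nM.

All three were measured in a functional assay on LNCaP cells (Homo sapiens) for antiproliferative activity, read by propidium iodide staining, with a stated time of 96 h; a lower number here means a stronger inhibitor, a higher number a weaker inhibitor. Compound 1 and compound 2 share a core, and the change between them, (a group of 4 heavy atoms (1 carbon, 3 fluorine; no ring) in place of a group of 6 heavy atoms (5 fluorine, 1 sulfur; no ring), on an aromatic carbon), gave a 1.0-fold lower number from compound 1 to compound 2 (0.01 log units; within the scatter). Compound 3 rests on a different core; the difference between its core and the core of compound 1 is not broken down here. Compound 4, `CC(O)(COc1ccc(C(F)(F)F)cc1)C(=O)Nc1cccc(S(F)(F)(F)(F)F)c1`, is not yet measured in this assay and differs from compound 3 by a group of 4 heavy atoms (1 carbon, 3 fluorine; no ring) in place of a group of 6 heavy atoms (5 fluorine, 1 sulfur; no ring), on an aromatic carbon. Around the place the two changes differ: in compound 1 the group that leaves sits meta to a large group, in compound 3 para to a large group, so the change is of the same kind, not the same. Resting on a 1.0-fold lower number from compound 1 to compound 2 (0.01 log units; within the scatter), which lay within the scatter, the expected step is no change at the digits printed from compound 3 to compound 4 (within the scatter). Compound 4 is thus estimated at 8000 nM, with a range from 4000 nM to 16000 nM.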

Compound 4, half-maximal inhibitory concentration: 9600 nM
For compound 4 the middle estimate is 1.2-fold (0.08 log units) below the measured one; measured number inside the range.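

In this assay, putting trifluoromethyl in place of the fluorinated sulfur group on the core of compound 3 gave a 1.2-fold higher number from compound 3 to compound 4 (0.08 log units; within the scatter). On these two cores the change thus behaved alike, with no difference that stands out from the scatter: the same change on two cores in this assay, a 1.0-fold lower number (0.01 log units; within the scatter) from compound 1 to compound 2 and a 1.2-fold higher number (0.08 log units; within the scatter) from compound 3 to compound 4, 1.2-fold (0.09 log units) apart, within the scatter of two such steps. Among the compounds shown here, this rests on only two pairs, and neither step is large, so it does not show that a step of real size would carry from one core to another, or that the two groups would match on other cores.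

The compounds shown leave open what a nitrile, an amine or a carboxylic acid would do on that aromatic carbon. Also open, going by these compounds, is whether the same change would be as small on the other aromatic ring, which keeps its fluorinated sulfur group in all four compounds.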